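This account rests on a few compounds, and the source may have more. Where it says the series, first, only, none or still open, it means among the compounds named here.

In an ADME assay on HeLa cells (Homo sapiens) for cytotoxicity, read by resazurin assay, with a stated time of 65 h (a lower number here means that less compound is needed, a higher number that more compound is needed for the effect), the measured compounds stand as follows:
Compound 1 `O=C(Nc1cccs1)c1ccc([N+](=O)[O-])o1`: > 20000 nM
Compound 2 `O=C(Nc1ccccc1)c1ccc([N+](=O)[O-])o1`: > 20000 nM

Compound 2 gives only the limit > 20000 nM and no number. Among the measured compounds shown here, it stands at the limit of > 20000 nM in this assay, at which 2 of the 2 values shown sit, with no measured step to go by. Compound 3 `O=C(Nc1cccc(C(F)(F)F)c1)c1ccc([N+](=O)[O-])o1` has trifluoromethyl in place of hydrogen on an aromatic carbon, meta to a large group, counted as trifluoromethyl in place of hydrogen on an aromatic carbon in full. In this assay a small move toward lower concentration is expected, but none beyond the scatter. The expected step is an at least 1.2-fold lower number from compound 2 to compound 3 (0.09 log units; that floor lies within the scatter) in size. Compound 3 is estimated at 16000 nM with an expected range from 7000 nM to 25000 nM and a good chance of another limit.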

Compound 3, half-maximal effective concentration: > 20000 nM
Compound 3 was reported as a limit; the forecaster's own chance of this, stated with the estimate: 65%; middle value at least 1.2-fold (0.09 log units) from the limit.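

In this assay compound 3 gives only a limit, > 20000 nM. Among the compounds shown here, compound 2 is also a limit, so no step between the two can be read. The compounds shown leave open whether trifluoromethyl in place of hydrogen on an aromatic carbon changes the concentration needed at all.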